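Swapping methyl for chloro on an aromatic ring

This account rests on a few compounds, and the source may have more. Where it says the series, first, only, none or still open, it means among the compounds named here.

Compound 1 `COC(=O)N1N=C(c2ccccc2)CC1c1cc(OC)c(OC)c(OC)c1`: 1080 nM
Compound 2 `COC(=O)N1N=C(c2cccc(C)c2)CC1c1cc(OC)c(OC)c(OC)c1`: 140 nM

Of the two compounds measured in a functional assay on MDA-MB-231 cells (Homo sapiens) for antiproliferative activity, read by MTT assay, with a stated time of 48 h (on this read-out higher numbers stand for weaker inhibition of growth and lower numbers for stronger inhibition of growth), compound 2 stands lowest, at 140 nM. Compound 3 `COC(=O)N1N=C(c2cccc(Cl)c2)CC1c1cc(OC)c(OC)c(OC)c1` differs from it in one place: chloro in place of methyl on an aromatic carbon. In words, this is chloro in place of methyl on an aromatic carbon, turning 3-methylphenyl into 3-chlorophenyl. Among the compounds with values here, one measured step bears on this: a 7.7-fold lower number from compound 1 to compound 2 (0.89 log units; beyond the scatter), with methyl in place of hydrogen on an aromatic carbon. Within the data shown here, it shows that a small group on this ring can move the number, but no chloro compound has been measured yet, so the comparison remains uncertain. Compound 3 is expected to stay closer to compound 2 than to compound 1 in this assay. The expected change is small, an estimated 1.4-fold higher number from compound 2 to compound 3 (0.15 log units; within the scatter). For compound 3 the estimated value is 200 nM, with an expected range of 70 nM to 600 nM.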

Compound 3, concentration for 50% growth inhibition: 110 nM
Compound 3: middle estimate off by 1.8-fold (0.26 log units), on the high side; the range from low to high includes it.
By their numbers in this assay, from the lowest: compounds 3 and 2 (each within the scatter of the next); then compound 1.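

In this assay, chloro in place of methyl gives a 1.3-fold lower number from compound 2 to compound 3 (0.10 log units; within the scatter), so the two groups cannot be told apart at this position. Chloro in place of hydrogen on the same carbon gives a 9.8-fold lower number from compound 1 to compound 3 (0.99 log units; beyond the scatter), which shows that the stronger growth inhibition seen with methyl is not unique to methyl, since a second group at this position also gives it. Nothing measured here accounts for the similar results of methyl and chloro.

As far as these compounds go, it remains open whether an ethyl chain, an amine or a carboxylic acid on this carbon would give a number close to those of compound 2 and compound 3. From the compounds shown here alone, it is also open whether methyl or chloro would give similar numbers on another carbon of the same ring.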